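The source may hold more compounds than are shown below. What is called first, only, known or untested is meant among the compounds shown, and "the series" means these compounds.

Notes on the chain substituent of the shared core, varied on the saturated chain carbon bound to a saturated ring carbon. Compound 1 `Cn1ncc(Cl)c1-c1cc(C(=O)N[C@@H]2CN[C@H](CC(O)CO)C[C@H]2c2ccc(Cl)c(Cl)c2)oc1Cl` gives 3.79 nM in an assay for inhibition of RAC-alpha serine/threonine-protein kinase (Homo sapiens), read by HTRF, with a stated time of 1 h; on this read-out higher numbers stand for weaker inhibition and lower numbers for stronger inhibition. Compound 2 `Cn1ncc(Cl)c1-c1cc(C(=O)N[C@@H]2CN[C@H](CC(=O)NC3CC3)C[C@H]2c2ccc(Cl)c(Cl)c2)oc1Cl` gives 3.95 nM, and compound 3 `Cn1ncc(Cl)c1-c1cc(C(=O)N[C@@H]2CN[C@H](CCN3CCCC3)C[C@H]2c2ccc(Cl)c(Cl)c2)oc1Cl` gives 6.41 nM, the highest of the three numbers, though each of its gaps to the others lies within the scatter. The three steps, a 1.0-fold higher number from compound 1 to compound 2 (0.02 log units; within the scatter), a 1.7-fold higher number from compound 1 to compound 3 (0.23 log units; within the scatter) and a 1.6-fold higher number from compound 2 to compound 3 (0.21 log units; within the scatter), are all within the scatter. Compound 4 `Cn1ncc(Cl)c1-c1cc(C(=O)N[C@@H]2CN[C@H](CC(=O)NCCO)C[C@H]2c2ccc(Cl)c(Cl)c2)oc1Cl` differs from compound 3 by (2-hydroxyethyl)carbamoyl in place of (pyrrolidin-1-yl)methyl on a saturated chain carbon bound to a saturated ring carbon. Since the change keeps a carbamoyl as in compound 2 at 3.95 nM and carries a hydroxyl as in compound 1 at 3.79 nM, no step beyond the scatter is expected: a 1.5-fold lower number from compound 3 to compound 4 (0.18 log units; within the scatter). Compound 4 is therefore estimated at 4.2 nM, within 2 nM to 9 nM.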

Compound 4, half-maximal inhibitory concentration: 1.41 nM
Compound 4: the middle estimate sits 3.0-fold (0.47 log units) above what was measured; measured number outside the range, below it.
By their numbers in this assay, from the lowest: compound 4; then compounds 1, 2 and 3 (each within the scatter of the next).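

Among the substituents on this saturated chain carbon, (2-hydroxyethyl)carbamoyl is the first to separate from the others, with a 4.5-fold lower number from compound 3 to compound 4 (0.66 log units; beyond the scatter) and a 2.7-fold lower number from compound 1 to compound 4 (0.43 log units; beyond the scatter). The carbamoyl alone does not carry this, as 2-hydroxyethyl in place of cyclopropyl on the amide-type nitrogen gives a 2.8-fold lower number from compound 2 to compound 4 (0.45 log units; beyond the scatter), so the group on that nitrogen matters at this position. No measurement here bears on the reason for these steps.

Still open, going by these compounds, is how far the hydroxyl itself counts: a 2-methoxyethyl or 3-hydroxypropyl group on the amide-type nitrogen would test this. On these data alone, a carboxylic acid on the same chain carbon also remains unexplored here.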